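This account rests on a few compounds, and the source may have more. Where it says the series, first, only, none or still open, it means among the compounds named here.

Compound 1: `CC(C(=O)NCc1ccc(C(C)(C)C)nc1SCCCN(C)C)c1ccc(NS(C)(=O)=O)c(F)c1`; in an assay on cells for antagonist activity at transient receptor potential cation channel subfamily V member 1 (Homo sapiens), read by FLIPR and calcium flux, with a stated time of 6 min (a higher number here means a weaker inhibitor, a lower number a stronger inhibitor), compound 1 gives 51.8 nM.
Compound 2: `CC(C(=O)NCc1ccc(C(C)(C)C)cc1N1CCCCC1)c1ccc(NS(C)(=O)=O)c(F)c1`; in this assay compound 2 gives 1.9 nM.

Of the two numbers, compound 2 has the lower one, and the gap from compound 1 to compound 2 lies beyond the usual scatter, so compound 2 is the stronger inhibitor of the pair. Compound 3, `CC(C(=O)NCc1ccc(C(C)(C)C)cc1N1CCN(c2ccccc2)CC1)c1ccc(NS(C)(=O)=O)c(F)c1`, has not yet been measured. It differs from compound 2 in one place: 4-phenylpiperazin-1-yl in place of piperidin-1-yl on an aromatic carbon. Going by the values given here, no step between two measured compounds shows what such a change does, so the expectation rests on the change itself: the entering group is larger and carries an additional ring. A modest loss is expected rather than a large shift, so the step from compound 2 to compound 3 is expected to be a 3.2-fold higher number from compound 2 to compound 3 (0.50 log units; beyond the scatter), toward a weaker inhibitor. Compound 3 is expected to give 6 nM in this assay, with a likely range from 1.5 nM to 30 nM.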

Compound 3, inhibition constant: 0.8 nM
Beside the measured number, compound 3's estimate is 7.5-fold (0.88 log units) above it; the whole stated range lies above it.
By their numbers in this assay, from the lowest: compound 3; then compound 2; then compound 1.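

This position, on an aromatic carbon ortho to a large group and meta to a tert-butyl group, accepts a much larger group than the piperidin-1-yl of compound 2. In this assay, 4-phenylpiperazin-1-yl in place of piperidin-1-yl gives a 2.4-fold lower number from compound 2 to compound 3 (0.38 log units; beyond the scatter) and so a modest gain in strength, showing that the additional aromatic ring does not cost activity here. No available data explain this gain or separate the contribution of the phenyl ring from that of the second ring nitrogen.

As far as these compounds go, whether the gain needs the phenyl ring remains open, and a 4-methylpiperazin-1-yl group or a piperazine with a free amine at this place would test that. Also open, from the compounds shown here alone, is how a chlorine or a methoxy group on the phenyl ring would shift the number.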